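Swapping a diethylaminoethyl tail for a hydroxyethyl chain

A few compounds are considered here, and "the series" means these few. Any claim that something is new, unique, unknown or untested is made for them only; others in the source may bear on it.

Of the compounds shown here, three on a shared core have been read in an in vitro ADME assay on microsomes from liver (Rattus norvegicus) for pharmacokinetics; on this read-out higher numbers stand for fast clearance and lower numbers for slow clearance. Compound 1 `Nc1nc(C(F)(F)F)cc2c1[nH]c(=O)n2Cc1ccc(NCCN2CCCC2)nc1` carries the (2-(pyrrolidin-1-yl)ethyl)amino group; in this assay compound 1 gives < 8.5 mL.min-1.g-1, which is a limit of the assay rather than a number. Compound 2 `CN(C)CCNc1ccc(Cn2c(=O)[nH]c3c(N)nc(C(F)(F)F)cc32)cn1` gives 16 mL.min-1.g-1 and compound 3 `CCN(CC)CCN(C)c1ccc(Cn2c(=O)[nH]c3c(N)nc(C(F)(F)F)cc32)cn1` gives 11 mL.min-1.g-1. Of the two numbers, compound 3 holds the lower, with compound 2 nearest, and the step of a 1.5-fold lower number from compound 2 to compound 3 (0.16 log units; within the scatter) stays within the scatter. The steps of an at least 1.8-fold higher number from compound 1 to compound 2 (0.27 log units; that floor lies within the scatter) and an at least 1.2-fold higher number from compound 1 to compound 3 (0.11 log units; that floor lies within the scatter) start from a limit (the limit of < 8.5 mL.min-1.g-1 in this assay, at which 1 of the 3 values shown sits).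

Compound 4 `Nc1nc(C(F)(F)F)cc2c1[nH]c(=O)n2Cc1ccc(NCCO)nc1` differs from compound 3 in one place: (2-hydroxyethyl)amino in place of (2-(diethylamino)ethyl)(methyl)amino on an aromatic carbon. Among the compounds with values here, no measured step replaces the dialkylamino end by a hydroxyl; the measured steps only exchange one dialkylamino end for another, and each stays within the scatter. Compound 4 is therefore expected to land close to compound 3, with the step of a 1.2-fold lower number from compound 3 to compound 4 (0.09 log units; within the scatter) expected to be small. For compound 4 the estimate in this assay is 9 mL.min-1.g-1, between 5 mL.min-1.g-1 and 17 mL.min-1.g-1.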

Compound 4, intrinsic clearance in microsomes: < 8.5 mL.min-1.g-1
Compound 4 was reported as a limit (the forecaster's own chance of this, stated with the estimate: 35%); middle value at least 1.0-fold (0.02 log units) away from the limit.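

In this assay, within the data shown here, the value of compound 4 is a limit and not a number, and it is the first read at this position for a chain ending in a hydroxyl rather than a dialkylamino group. The steps of an at least 1.2-fold lower number from compound 3 to compound 4 (0.11 log units; that floor lies within the scatter) and an at least 1.8-fold lower number from compound 2 to compound 4 (0.27 log units; that floor lies within the scatter) give only floors, so the hydroxyl end is shown to be compatible with slow clearance in this read-out, but not to slow clearance relative to compound 2 or compound 3. The step between compound 1 and compound 4 cannot be read, and the two now share one limit: the limit of < 8.5 mL.min-1.g-1 in this assay, at which 2 of the 4 values shown sit.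

What number lies behind the limit of compound 4 remains open. Also open, on these data alone, is how a methoxy end, a carboxylic acid or a longer chain carrying the hydroxyl would read at this position.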